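Adding a nitro group to compound 3

This account rests on a few compounds, and the source may have more. Where it says the series, first, only, none or still open, it means among the compounds named here.

Compound 3 (`CC(C)(C)NCc1c(C(=O)O)nn(-c2ccc(Cl)cc2)c1-c1ccccc1`) gives > 652000 nM in a functional assay on PC-3 cells (Homo sapiens) for inhibition, read by sulforhodamine B assay, with a stated time of 48 h (on this read-out lower numbers stand for stronger inhibition of growth and higher numbers for weaker inhibition of growth), and this value is a limit, not a measured number. Compound 2 (`CC(C)(C)NCc1c(C(=O)O)nn(-c2ccc(Cl)cc2)c1-c1ccc(Cl)cc1`) gives > 599000 nM, which is also a limit. Among the compounds with values here, the only measured step is a step that the two limits leave unreadable from compound 2 to compound 3, where hydrogen takes the place of chloro. Compound 4 (`CC(C)(C)NCc1c(C(=O)O)nn(-c2ccc(Cl)cc2)c1-c1ccc([N+](=O)[O-])cc1`) differs from compound 3 by nitro in place of hydrogen on an aromatic carbon, turning phenyl into 4-nitrophenyl. Compound 1 (`CCOC(=O)c1nn(-c2ccc(Cl)cc2)c(-c2ccc([N+](=O)[O-])cc2)c1CNC(C)(C)C`) also carries 4-nitrophenyl, differs elsewhere, and gives > 548000 nM; 304000 nM (2 entries). On these values, no change beyond the scatter is expected in this assay, and the expected step is an at least 1.1-fold lower number from compound 3 to compound 4 (0.05 log units; that floor lies within the scatter). Compound 4 is estimated at 580000 nM, with an expected range from 300000 nM to 900000 nM.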

Compound 4, concentration for 50% growth inhibition: > 583000 nM
Compound 4: a limit, no number; the forecaster's own chance of this, stated with the estimate: 75%; middle value at least 1.0-fold (0.00 log units) from the limit.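

Within the data shown here, compound 2, compound 3 and compound 4 all give limits, not numbers, and no step among them can be read. Going by these compounds, whether hydrogen, chloro or nitro on this aromatic carbon changes growth inhibition in this assay stays open.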